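A Smaller Phenyl Group and Adenosine Receptor Binding

This account rests on a few compounds, and the source may have more. Where it says the series, first, only, none or still open, it means among the compounds named here.

Of the compounds shown here, three of a shared core have been measured in an assay on CHO cells for displacement of a labelled ligand from adenosine receptor A1 (Homo sapiens); on this read-out lower numbers stand for stronger inhibition and higher numbers for weaker inhibition. Compound 1 `CCn1c(=O)c2nc(-c3cnn(Cc4cccc(F)c4)c3)[nH]c2n(CC)c1=O` gives 380 nM, compound 2 `CCCn1c(=O)c2nc(-c3cnn(Cc4cc(C(F)(F)F)ccc4Cl)c3)[nH]c2n(CCC)c1=O` gives 1200 nM, and compound 3 `CCCn1c(=O)c2[nH]c(-c3cnn(Cc4ccccc4)c3)nc2n(CCC)c1=O` gives 76 nM. Compound 2 thus stands at the highest number of the three, with compound 1 and compound 3 both lower by margins beyond the scatter. Compound 4 `CCCn1c(=O)c2nc(-c3cnn(Cc4cccc(Cl)c4)c3)[nH]c2n(CCC)c1=O` is not yet measured and differs from compound 2 in one place: 3-chlorophenyl in place of 2-chloro-5-(trifluoromethyl)phenyl on a saturated chain carbon bound to an aromatic nitrogen. Going by the values given here, no pair of measured compounds isolates this change. Compound 3, which carries an unsubstituted phenyl on that carbon, gives 76 nM. A lower number is therefore expected for compound 4, estimated as a step of an 8.0-fold lower number from compound 2 to compound 4 (0.90 log units; beyond the scatter) in this assay. Compound 4 is expected to give 150 nM, between 50 nM and 500 nM.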

Compound 4, inhibition constant: 31 nM
Beside the measured number, compound 4's estimate is 4.8-fold (0.68 log units) above it; measured number outside the range, below it.
By their numbers in this assay, from the lowest: compound 4; then compound 3; then compound 1; then compound 2.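

In this assay the change to 3-chlorophenyl in place of 2-chloro-5-(trifluoromethyl)phenyl, on a saturated chain carbon bound to an aromatic nitrogen, gives a 39-fold lower number from compound 2 to compound 4 (1.59 log units; beyond the scatter) and is a large step. Going by these compounds alone, it is the only step here that isolates a single change, and it shows that the group carried on this carbon can strongly shift the number. Nothing available explains the size of this step. The compounds shown leave open how much of it follows from losing the trifluoromethyl group alone. They also leave open how a methoxy group or a nitrile on this phenyl ring would read.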